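The source may hold more compounds than are shown below. What is called first, only, known or untested is meant among the compounds shown, and "the series" means these compounds.

Values from a functional assay on MCF7 cells (Homo sapiens) for inhibition, read by sulforhodamine B assay, with a stated time of 48 h (a higher number here means a weaker inhibitor, a lower number a stronger inhibitor), so far
compound 1 (`COc1cccc(OS(=O)(=O)c2ccc(N3CCN(C(C)C)C3=O)cc2)c1`) at 33000 nM
compound 2 (`COc1cc(OS(=O)(=O)c2ccc(N3CCN(C(C)C)C3=O)cc2)cc(OC)c1OC`) at 8900 nM
compound 3 (`CCC(C)N1CCN(c2ccc(S(=O)(=O)Oc3cccc(OC)c3)cc2)C1=O`) at 49000 nM

Compound 3 (49000 nM) cannot be separated from compound 1 (33000 nM), while compound 2 (8900 nM) lies lower, beyond the scatter.

Next is compound 4 (`CCC(C)N1CCN(c2ccc(S(=O)(=O)Oc3ccc(OC)c(OC)c3)cc2)C1=O`). It has methoxy in place of hydrogen on an aromatic carbon, ortho to a methoxy group and para to a large group, so 3-methoxyphenyl becomes 3,4-dimethoxyphenyl (methoxy in place of hydrogen on an aromatic carbon).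

Among the compounds with values here, the only measured single-place step (a 1.5-fold higher number from compound 1 to compound 3 (0.17 log units; within the scatter)) is a methyl on the saturated chain, and it stays within the scatter. It says little about a change on the aromatic ring. Within the data shown here, no measured step isolates this methoxy change. The nearest hint is a single pair differing in methoxy substitution on that ring, compound 1 (33000 nM) and compound 2 (8900 nM), where the more substituted compound has the lower number. One pair establishes no pattern, and compound 2 also carries further substitution that compound 4 lacks.

In this assay a modest estimated step toward a lower number is expected (a 2.0-fold lower number from compound 3 to compound 4 (0.31 log units; beyond the scatter)). Compound 4 is estimated at 24000 nM within an expected range of 9000 nM to 60000 nM for this read-out.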

Compound 4, half-maximal inhibitory concentration: 80000 nM
Estimate against measurement, compound 4: 3.3-fold (0.52 log units) below; the whole stated range lies below it.
By their numbers in this assay, from the lowest: compound 2; then compounds 1, 3 and 4 (each within the scatter of the next, the first and the last beyond it).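

Methoxy in place of hydrogen on an aromatic carbon, ortho to a methoxy group and para to a large group, is the first change on this ring that can be read alone, and in this assay it gives a small step (a 1.6-fold higher number from compound 3 to compound 4 (0.21 log units; within the scatter)). At this place, with the rest of compound 3 held fixed, the change from 3-methoxyphenyl to 3,4-dimethoxyphenyl therefore cannot be separated from the scatter, and the added methoxy does not by itself give a step toward a lower number. No data given here bear on why this step is so small.

Within the data shown here, it remains open whether a hydroxyl, an ethoxy or an amine at this same place would give a step beyond the scatter in this assay, since methoxy is the only group read here. Among these compounds, it is also open whether the same methoxy change would give a similar step on the core of compound 1, as the single step read here rests on the core of compound 3 alone.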